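The source may report more compounds than this note shows. Statements on the series, on what has been measured and on what is new or still open speak of the compounds shown alone.

Compound 1 `CC(C)C(c1ccc(-c2ccc3cccc(F)c3c2)[nH]c1=O)C1NC(=O)NC1=O`: 0.578 h
Compound 2 `CCC(/C=C1\OC(=O)NC1=O)(CC)c1ccc(-c2ccc3cc(F)cc(F)c3c2)[nH]c1=O`: > 3 h
Compound 3 `CC(C)C(c1ccc(-c2ccc3cccc(F)c3c2)[nH]c1=O)C1C(=O)NC(=O)N1C`: not yet measured

Going by the values given here, in an ADME assay on microsomes from liver (Homo sapiens) for metabolic stability (on this read-out lower numbers stand for a shorter-lived compound and higher numbers for a longer-lived compound), compound 1 gives 0.578 h, the only exact number so far. Compound 2 shows > 3 h, which is a limit and not a number. Compound 3 differs from compound 1 in one place: methyl in place of hydrogen on an amide-type nitrogen in a ring, a methyl in place of hydrogen on an amide-type nitrogen in a ring. Among the compounds with values here, no measured pair shows this change, so nothing beyond the usual scatter is expected in this assay. The expected change is a 1.2-fold lower number from compound 1 to compound 3 (0.06 log units; within the scatter). For compound 3, the estimated value is 0.5 h, with an expected range of 0.25 h to 1.1 h.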

Compound 3, half-life: 0.375 h
Estimate against measurement, compound 3: 1.3-fold (0.12 log units) above, and the stated range covers the measured number.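

In this assay, going by these compounds alone, the first step that can be read at this position is a 1.5-fold lower number from compound 1 to compound 3 (0.19 log units; within the scatter). Putting a methyl on this ring nitrogen, and so removing the amide hydrogen, therefore gives compound 3 a half-life that cannot be told apart from that of compound 1. Nothing shown gives a reason for the size of this step.

This is a single step on a single core, so it sets no general rule. Going by these compounds, whether an ethyl group, a longer chain or a chain ending in an amine on this nitrogen would shift the half-life beyond the usual scatter remains open.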